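A few compounds are considered here, and "the series" means these few. Any claim that something is new, unique, unknown or untested is made for them only; others in the source may bear on it.

Measured so far in an assay on HEK293 cells for inhibition of Voltage-dependent T-type calcium channel subunit alpha-1H (Homo sapiens), read by FLIPR and calcium flux, with a stated time of 3 min; a higher number here means a weaker inhibitor, a lower number a stronger inhibitor:

compound 1, `C[C@@H]1CN(Cc2ccccc2)c2ncccc2[C@H](C)N1C(=O)NCc1ccccc1`: 31 nM
compound 2, `C[C@@H]1CN(Cc2ccccc2)c2c(cnn2C)[C@H](C)N1C(=O)NCc1ccccc1`: > 7300 nM
compound 3, `C[C@@H]1CN(Cc2ccccc2)c2cncc(F)c2[C@H](C)N1C(=O)NCc1ccccc1`: 72 nM

All three share the same core and differ in the aromatic ring fused to it. In this assay compound 1 gives 31 nM. For compound 2 the assay reports only a limit, > 7300 nM, so no number is known for it; this is the case described by the limit of > 7300 nM in this assay, at which 1 of the 3 values shown sits. Compound 3 gives 72 nM, which is the higher of the two numbers shown, and its gap to compound 1 lies beyond the usual scatter of repeated measurements.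

The next compound, compound 4 `C[C@@H]1CN(Cc2ccccc2)c2cncc(F)c2[C@H](C)N1C(=O)Nc1cccnc1`, keeps the core of compound 3 and changes only the group on the amide-type nitrogen: pyridin-3-yl in place of benzyl on an amide-type nitrogen. No measured pair shows this change, so the expected size of the step rests on judgement rather than on a shown step. The change is expected to shift the number modestly toward weaker inhibition, with an estimated step of a 2.8-fold higher number from compound 3 to compound 4 (0.44 log units; beyond the scatter). Compound 4 is therefore estimated to give about 200 nM in this assay, with a likely range from 50 nM to 1500 nM.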

Compound 4, half-maximal inhibitory concentration in the Voltage-dependent T-type calcium channel subunit alpha-1H assay: 240 nM
For compound 4 the middle estimate is 1.2-fold (0.08 log units) below the measured one; the measured number falls inside the stated range.
By their numbers in the Voltage-dependent T-type calcium channel subunit alpha-1H assay, from the lowest: compound 1; then compound 3; then compound 4. At a limit, above all of these: compound 2.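

Compounds 1, 2 and 3 all carry benzyl on the amide-type nitrogen, so compound 4 is the only one shown in which this position varies, and in the Voltage-dependent T-type calcium channel subunit alpha-1H assay the swap to pyridin-3-yl gives a modest loss of inhibition: a 3.3-fold higher number from compound 3 to compound 4 (0.52 log units; beyond the scatter). The entering group has one hetero atom and one hydrogen-bond acceptor that benzyl lacks and one heavy atom fewer, but no measurement shown accounts for the step. In a physicochemical assay for lipophilicity, at pH 7.4 (a lower number here means a more polar compound, a higher number a more lipophilic compound), compound 4 gives 3.3, while the entry for compound 3 reads "not determined" (no result reported), so no step can be read between them in this assay.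

Going by these compounds, compound 3 and compound 4 differ both in the ring and in how it is attached, so it stays open which of the two changes carries the step. A plain phenyl group or a pyridin-3-ylmethyl group on the same nitrogen would separate the two, and either would show whether the ring nitrogen or the loss of the carbon link matters more.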